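Clearance notes: pyridin-2-yl for methoxymethyl on compound 2

This account rests on a few compounds, and the source may have more. Where it says the series, first, only, none or still open, it means among the compounds named here.

Going by the values given here, in an ADME assay on microsomes from liver (Homo sapiens) for metabolic stability (on this read-out lower numbers stand for slow clearance and higher numbers for fast clearance), compound 2 `COCc1cn(CCCCO)c(Cn2c(=O)n(C3CC3)c3ccncc32)n1` gives 9 mL.min-1.g-1, the lowest of the two numbers so far. Its nearest neighbour is compound 1 `CC(C)n1nc(Cn2nc3ccccc3c2OCCCO)c2ccccc21`, which in this assay gives 246 mL.min-1.g-1, a gap well beyond the scatter. Compound 3 `O=c1n(Cc2nc(-c3ccccn3)cn2CCCCO)c2cnccc2n1C1CC1` is still unmeasured and differs from compound 2 by one change: pyridin-2-yl in place of methoxymethyl on an aromatic carbon. Among the compounds with values here, no step between measured compounds covers this change, so the expectation rests on compound 2 alone. A rise of modest size, close to the scatter edge, is estimated in this assay, giving a 1.6-fold higher number from compound 2 to compound 3 (0.19 log units; within the scatter). Compound 3 is expected near 14 mL.min-1.g-1, with a range from 6 mL.min-1.g-1 to 40 mL.min-1.g-1.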

Compound 3, intrinsic clearance in microsomes: < 8 mL.min-1.g-1
Compound 3 was reported as a limit; the forecaster's own chance of this, stated with the estimate: 5%; at least 1.7-fold (0.24 log units) between middle value and limit.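

In this assay, pyridin-2-yl on this aromatic carbon, two ring bonds from the ring atom that bears a 4-hydroxybutyl group, gives an at least 1.1-fold lower number from compound 2 to compound 3 (0.05 log units; that floor lies within the scatter). Compound 3 is reported as a limit, not a number: the limit of < 8 mL.min-1.g-1 in this assay, at which 1 of the 3 values shown sits. This position therefore takes an aromatic ring in place of methoxymethyl with the read-out still at the low end of the values shown.

On these data alone, the full size of the step stays open, since only its floor can be read. Also open, as far as these compounds go, is whether an amine or a carboxylic acid on this carbon would give a similarly low number.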